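The source may hold more compounds than are shown below. What is called first, only, known or untested is meant among the compounds shown, and "the series" means these compounds.

Among the compounds with values here, compound 1, with the structure `NC(=O)c1c(NC(=O)c2ccccc2Br)sc2c1CCN(C(=S)Nc1ccccc1Br)C2`, is the only member of this small set that yields an actual number in a functional assay on MKN-74 cells (Homo sapiens) for antiproliferative activity, with a stated time of 24 h (on this read-out higher numbers stand for weaker inhibition and lower numbers for stronger inhibition), where compound 1 gives 13700 nM. Compound 2, with the structure `Cc1ccccc1NC(=S)N1CCc2c(sc(NC(=O)c3ccccc3Br)c2C(N)=O)C1`, reaches only a limit of the assay: in this assay compound 2 gives > 50000 nM. Within the data shown here, the one measured step, an at least 3.6-fold higher number from compound 1 to compound 2 (0.56 log units; beyond the scatter), comes from methyl in place of bromo on an aromatic carbon, and the size of that step is bounded by the limit of > 50000 nM in this assay, at which 1 of the 2 values shown sits.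

Compound 3, with the structure `NC(=O)c1c(NC(=O)c2ccccc2C(F)(F)F)sc2c1CCN(C(=S)Nc1ccccc1Br)C2`, differs from compound 1 by trifluoromethyl in place of bromo on an aromatic carbon, that is, 2-bromophenyl to 2-(trifluoromethyl)phenyl. Among the measured compounds shown here, no measured step covers this exact change; the only step available shows that replacing a bromo group weakened inhibition at least modestly, so a similar direction is expected here, though trifluoromethyl is a different substituent from methyl and the replacement sits elsewhere in the molecule. For compound 3 a step of a 1.6-fold higher number from compound 1 to compound 3 (0.21 log units; within the scatter) is expected in this assay, and compound 3 is therefore estimated at 22000 nM, within a range of 8000 nM to 50000 nM.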

Compound 3, half-maximal inhibitory concentration: 23900 nM
For compound 3 the middle estimate is 1.1-fold (0.04 log units) below the measured one; low and high end bracket the measured number.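

In this assay, the change from 2-bromophenyl to 2-(trifluoromethyl)phenyl gives a 1.7-fold higher number from compound 1 to compound 3 (0.24 log units; within the scatter), so at this position trifluoromethyl, with 4 heavy atoms in place of the single bromine, leaves the number without a readable change. Within the data shown here, this is the first information about this 2-bromophenyl, since the earlier step, an at least 3.6-fold higher number from compound 1 to compound 2 (0.56 log units; beyond the scatter), concerns the other 2-bromophenyl of compound 1 and a different incoming group, so the weakening seen there cannot be carried over to this position. Nothing shown gives a reason for this outcome.

It remains open whether trifluoromethyl would also leave the number unchanged on the other 2-bromophenyl, where only the swap to methyl is shown. From the compounds shown here alone, it is also open whether this position would accept a group of a quite different kind, such as an amine or a carboxylic acid, in place of bromo, or whether the match between bromo and trifluoromethyl is a special case among the groups that could sit there.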